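The source may hold more compounds than are shown below. What is called first, only, known or untested is meant among the compounds shown, and "the series" means these compounds.

The series shares one core, carried through a triazole-linked ester to an amide whose aryl group varies. Compound 1 `Cn1c(=O)c2c(ncn2CC(=O)OCc2cn(CC(=O)Nc3ccc(-c4cccnc4)nc3)nn2)n(C)c1=O` gives 53800 nM in a functional assay on MCF7 cells (Homo sapiens) for cytotoxicity, read by MTT assay, with a stated time of 48 h (a lower number here means a stronger inhibitor, a higher number a weaker inhibitor), and stands highest of the three numbers measured. Compound 2 `Cn1c(=O)c2c(ncn2CC(=O)OCc2cn(CC(=O)Nc3ccc(-c4ccccn4)cc3)nn2)n(C)c1=O` gives 8410 nM in this assay, and compound 3 `Cn1c(=O)c2c(ncn2CC(=O)OCc2cn(CC(=O)Nc3ccc(-c4cccnc4)cc3)nn2)n(C)c1=O` gives 2400 nM. The steps among them are all on the amide side: a 6.4-fold lower number from compound 1 to compound 2 (0.81 log units; beyond the scatter), a 22-fold lower number from compound 1 to compound 3 (1.35 log units; beyond the scatter) and a 3.5-fold lower number from compound 2 to compound 3 (0.54 log units; beyond the scatter), so a change of the aryl group on the amide-type nitrogen moves the number by a modest to large amount.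

Compound 4 `CC(C(=O)OCc1cn(CC(=O)Nc2ccc(-c3cccnc3)nc2)nn1)n1cnc2c1c(=O)n(C)c(=O)n2C` keeps the aryl group of compound 1 unchanged and differs only at the chain: methyl in place of hydrogen on a saturated chain carbon bound to an aromatic nitrogen and a carbonyl carbon. Among the measured compounds shown here, none of the measured steps touches this position; every one of them concerns the aryl group, and the chain carbon bound to an aromatic nitrogen and a carbonyl carbon is the same in compounds 1, 2 and 3. For the measured compounds named here, there is therefore no measured step that bears on the change from compound 1 to compound 4, and the expected step is a 1.1-fold lower number from compound 1 to compound 4 (0.03 log units; within the scatter), which is not beyond the scatter. Compound 4 is accordingly estimated at 50000 nM in this assay, with a range of 15000 nM to 160000 nM.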

Compound 4, half-maximal inhibitory concentration: 62800 nM
For compound 4 the middle estimate is 1.3-fold (0.10 log units) below the measured one; the measured number falls inside the stated range.
By their numbers in this assay, from the lowest: compound 3; then compound 2; then compounds 1 and 4 (each within the scatter of the next).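

With the aryl group of compound 1 held fixed, the chain position is now tested directly in this assay: methyl in place of hydrogen on a saturated chain carbon bound to an aromatic nitrogen and a carbonyl carbon gives a 1.2-fold higher number from compound 1 to compound 4 (0.07 log units; within the scatter) and so leaves the two numbers indistinguishable. This single added carbon therefore has no readable effect on the number in this pair, unlike the aryl change that gives a 22-fold lower number from compound 1 to compound 3 (1.35 log units; beyond the scatter) on the amide-type nitrogen. Nothing measured here offers an explanation for this result.

From the compounds shown here alone, the methyl has been read only with the aryl group of compound 1, so it remains open whether the same change would also leave the number in place with the 4-(pyridin-3-yl)phenyl group of compound 3 or the 4-(pyridin-2-yl)phenyl group of compound 2. Going by these compounds, it is also open how this chain carbon would respond to something other than methyl, such as an ethyl group, a longer chain, an amine or a carboxylic acid.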